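A 3-sulfopropyl tail in place of the ring pair

A few compounds are considered here, and "the series" means these few. Any claim that something is new, unique, unknown or untested is made for them only; others in the source may bear on it.

In an assay on HEK293 cells for displacement of a labelled ligand from 5-hydroxytryptamine receptor 4 (Homo sapiens), read by scintillation counting (on this read-out lower numbers stand for stronger inhibition and higher numbers for weaker inhibition), the measured compounds are:
compound 1 `CCN1CCC(NC(=O)c2cc(Cl)c(N)cc2OC)CC1` gives 1000 nM
compound 2 `COc1cc(N)c(Cl)cc1C(=O)NC1CCN(CCCCCCCCO)CC1` gives 79.4 nM
compound 3 `COc1cc(N)c(Cl)cc1C(=O)NC1CCN(CCCCCN2C(=O)c3ccccc3C2=O)CC1` gives 20 nM

Compound 3 has the lowest number of the three: the step of a 4.0-fold lower number from compound 2 to compound 3 (0.60 log units; beyond the scatter) is beyond the scatter, and compound 1 lies further away still. Compound 4 `COc1cc(N)c(Cl)cc1C(=O)NC1CCN(CCCCCCCCS(=O)(=O)O)CC1` differs from compound 3 by a group of 7 heavy atoms (3 carbon, 3 oxygen, 1 sulfur; no ring) in place of a group of 11 heavy atoms (8 carbon, 1 nitrogen, 2 oxygen; one five-membered non-aromatic ring with 1 hetero atom, one six-membered aromatic ring of carbon only), on a saturated chain carbon, five bonds along the chain from an amine nitrogen in a ring. Going by the values given here, two measured steps bear on this. The step of a 13-fold lower number from compound 1 to compound 2 (1.10 log units; beyond the scatter) shows how much a long chain on the ring nitrogen changes the number; the step of a 4.0-fold lower number from compound 2 to compound 3 (0.60 log units; beyond the scatter) shows the ring pair at the chain end outperforming a small, ring-free end. Compound 4 keeps the long chain but returns to a small, ring-free end, so a modest rise in number is expected: a 5.0-fold higher number from compound 3 to compound 4 (0.70 log units; beyond the scatter). Compound 4 is therefore estimated at 100 nM in this assay, within 30 nM to 320 nM.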

Compound 4, inhibition constant: 15800 nM
For compound 4 the middle estimate is 160-fold (2.20 log units) below the measured one; the measured number lies above the stated range.
By their numbers in this assay, from the lowest: compound 3; then compound 2; then compound 1; then compound 4.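

In this assay, a small, ring-free end on this long chain is not enough to predict the outcome: sulfo in place of hydroxy gives a 200-fold higher number from compound 2 to compound 4 (2.30 log units; beyond the scatter), and the 3-sulfopropyl tail in place of the ring pair gives a 790-fold higher number from compound 3 to compound 4 (2.90 log units; beyond the scatter). The long chain can even lose its advantage over the ethyl group, since the change gives a 16-fold higher number from compound 1 to compound 4 (1.20 log units; beyond the scatter). Nothing measured here explains this change.

On these data alone, it remains open whether a carboxylic acid or an amine at the chain end would behave like sulfo. As far as these compounds go, a shorter or longer chain carrying sulfo also remains untested here.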